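Swapping the Naphthyl Arm for a Trifluoromethylphenyl

The source may hold more compounds than are shown below. What is called first, only, known or untested is meant among the compounds shown, and "the series" means these compounds.

Measured compounds:
compound 1 `Cc1cc(-c2ccccc2)n(/C(N)=N/S(=O)(=O)c2cc(C)c(Cl)cc2SCc2cccc3ccccc23)n1` — 7000 nM
compound 2 `Cc1cc(-c2ccccc2)n(/C(N)=N/S(=O)(=O)c2cc(C)c(Cl)cc2SCc2cccc(C(F)(F)F)c2)n1` — 19000 nM
compound 3 `Cc1cc(S(=O)(=O)/N=C(\N)n2nccc2-c2ccccc2)c(SCc2cccc3ccccc23)cc1Cl` — 7000 nM

The unmeasured compound is compound 4 `Cc1cc(S(=O)(=O)/N=C(\N)n2nccc2-c2ccccc2)c(SCc2ccccc2C(F)(F)F)cc1Cl`.

All numbers come from a functional assay on HCT-116 cells (Homo sapiens) for cytotoxicity, read by MTT assay, with a stated time of 72 h; on this read-out higher numbers stand for weaker inhibition and lower numbers for stronger inhibition. Compound 3 gives 7000 nM there and stands level with compound 1, the two together holding the lowest numbers of the three; it is furthest from compound 2, where the step from compound 1 reads a 2.7-fold higher number from compound 1 to compound 2 (0.43 log units; beyond the scatter). The step from compound 1 to compound 3 itself is no change at the digits printed from compound 1 to compound 3 (within the scatter), so the methyl on the shared core makes no difference that the assay can resolve.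

The change to compound 4 is 2-(trifluoromethyl)phenyl in place of naphthalen-1-yl on a saturated chain carbon bound to a sulfur. Cut one bond further out, it reads (naphthalen-1-yl)methyl to 2-(trifluoromethyl)benzyl. Among the compounds with values here, no measured pair shows exactly this move; the nearest is the step from compound 1 to compound 2, which replaced naphthalen-1-yl with 3-(trifluoromethyl)phenyl at the same place and gave a 2.7-fold higher number from compound 1 to compound 2 (0.43 log units; beyond the scatter). Compound 4 differs in carrying the trifluoromethyl as a 2-(trifluoromethyl)phenyl, so the size is uncertain, but a modest rise is the expected direction.

Compound 4 is therefore estimated at 15000 nM, within 7000 nM to 35000 nM, an expected step of a 2.1-fold higher number from compound 3 to compound 4 (0.33 log units; beyond the scatter) from compound 3.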

Compound 4, half-maximal inhibitory concentration: 16000 nM
Compound 4: middle estimate off by 1.1-fold (0.03 log units), on the low side; the measured number falls inside the stated range.
By their numbers in this assay, from the lowest: compounds 1 and 3 (each within the scatter of the next); then compounds 4 and 2 (each within the scatter of the next).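

In this assay the rise first seen on the methyl-bearing core now appears on the core without that methyl (a 2.3-fold higher number from compound 3 to compound 4 (0.36 log units; beyond the scatter)), so replacing naphthalen-1-yl at this saturated chain carbon bound to a sulfur raises the number on both cores shown. Within the data shown here, it also shows that this direction is not confined to 3-(trifluoromethyl)phenyl, since 2-(trifluoromethyl)phenyl goes the same way, and no compound here goes against it. The entering group has the same count of 10 heavy atoms as the group it replaces, but one aromatic ring rather than two, so the rise does not go with a change in heavy-atom count.

Compound 2 and compound 4 differ in two places, so the placement of the trifluoromethyl cannot be read apart from the core methyl, and a plain benzyl, a chlorine or a methoxy in place of the trifluoromethyl, or a naphthalen-2-yl, would be needed to separate the loss of the second ring from the arrival of the trifluoromethyl. No measurement shown here explains the rise on either core.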